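A few compounds are considered here, and "the series" means these few. Any claim that something is new, unique, unknown or untested is made for them only; others in the source may bear on it.

Measured compounds:
compound 1, `Cc1cc(C(=O)O)ccc1CN1CCC[C@H](O[C@H](CF)c2cc(Cl)cc(Cl)c2)[C@@H]1c1ccccc1`: 9100 nM
compound 2, `Cc1cc(C(=O)O)ccc1CN1CCC[C@H](O[C@H](CO)c2cc(Cl)nc(Cl)c2)[C@@H]1c1ccccc1`: 2400 nM

Within the data shown here, in an assay on isolated protein for activation of cGMP-dependent protein kinase 1 (Homo sapiens), read by ADP-Glo, with stated times of 30 min and 2 h, in the presence of a further agent that is not named here (a lower number here means that less compound is needed, a higher number that more compound is needed for the effect), compound 1 gives the higher of the two numbers recorded, and the only neighbour, compound 2, sits a step away: a 3.8-fold lower number from compound 1 to compound 2 (0.58 log units; beyond the scatter). That step exchanged the whole side group on the oxygen, a group with a carbon-only ring for one holding a nitrogen-containing ring and a hydroxyl, so it does not isolate any single part of the change.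

Compound 3, `Cc1cc(C(=O)O)ccc1CN1CCC[C@H](O[C@H](CS(C)(=O)=O)c2cc(Cl)cc(Cl)c2)[C@@H]1c1ccccc1`, differs from compound 1 in one place only: methylsulfonyl in place of fluoro on a saturated chain carbon, two bonds along the chain from an aromatic carbon and an oxygen on a saturated carbon. Among the measured compounds shown here, no measured pair tests this exchange on its own; the step from compound 1 to compound 2 touched the same chain carbon but altered the ring at the same time, so it offers only loose guidance. With that thin basis the expectation for compound 3 in this assay is a number close to that of compound 1, with a modest improvement judged somewhat more likely than a loss: a 1.7-fold lower number from compound 1 to compound 3 (0.22 log units; within the scatter). The estimate for compound 3 is therefore 5500 nM, within a wide range of 1500 nM to 20000 nM.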

Compound 3, half-maximal effective concentration: 330 nM
Compound 3: middle estimate off by 17-fold (1.22 log units), on the high side; measured number below the stated range.
By their numbers in this assay, from the lowest: compound 3; then compound 2; then compound 1.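

In this assay, exchanging a single group on this saturated chain carbon, methylsulfonyl in place of fluoro, gives a 28-fold lower number from compound 1 to compound 3 (1.44 log units; beyond the scatter) with the rest of the molecule unchanged. Among these compounds, the earlier step, a 3.8-fold lower number from compound 1 to compound 2 (0.58 log units; beyond the scatter), changed the ring and the chain group together, so only this new step shows that the chain group alone can shift the number, and by a large amount. The entering group brings more heavy atoms and two hydrogen-bond acceptors where fluoro had none, but no measurement here connects either feature to the result or explains it.

The compounds shown leave open whether the sulfur group itself matters or whether other groups with more heavy atoms than fluoro on this carbon would give a similar number. Ethylsulfonyl, with a longer chain on the sulfur, or an amide or an amine on the same carbon could help separate these possibilities, and it also remains open whether methylsulfonyl would give a similar step alongside the nitrogen-containing ring of compound 2.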